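The compounds below may be only part of what the source reports. "The series", "measured", "known", "first", "only" and "open" are said of these compounds alone.

Measured so far in a functional assay on MDA-MB-231 cells (Homo sapiens) for cytotoxicity, read by MTT assay, with a stated time of 72 h; on this read-out lower numbers stand for an effect already at smaller amounts and higher numbers for an effect only at larger amounts of compound:
- compound 1 `CCc1cccc2c(OC)c(-c3occ(C)c3C(=O)OC)ccc12`: 1.3 ug/mL
- compound 2 `CCc1cccc2c(OC)c(-c3occ(C)c3C(=O)NC)ccc12`: > 10 ug/mL, which is a limit of this assay and not a number
- compound 3 `CCc1cccc2c(OC)c(-c3occ(C)c3COC)ccc12`: 9.7 ug/mL

Compound 3 holds the highest of the two numbers. Its nearest neighbour is compound 1, and the step of a 7.5-fold higher number from compound 1 to compound 3 (0.87 log units; beyond the scatter) is beyond the scatter. Against compound 2 the comparison stays open, since an at least 1.0-fold lower number from compound 2 to compound 3 (0.01 log units; that floor lies within the scatter) has its floor within the scatter and compound 2 shows only a limit.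

Compound 4 `CCc1cccc2c(OC)c(-c3occ(C)c3COC(C)=O)ccc12` differs from compound 3 by acetyl in place of methyl on an oxygen on a saturated carbon, in words acetyl in place of methyl on an oxygen on a saturated carbon. The measured steps that touch this position are a 7.5-fold higher number from compound 1 to compound 3 (0.87 log units; beyond the scatter), where the methoxycarbonyl of compound 1 gave way to methoxymethyl, and an at least 7.6-fold higher number from compound 1 to compound 2 (0.88 log units; beyond the scatter), where the ester oxygen became methylamino. Neither reproduces the present change; both show that reshaping this group moves the number by a modest amount. For compound 4 the step of a 1.6-fold lower number from compound 3 to compound 4 (0.21 log units; within the scatter) is therefore expected to be small against this background. Compound 4 is estimated at 6 ug/mL, within 2 ug/mL to 15 ug/mL.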

Compound 4, concentration for half-maximal effect: 3.5 ug/mL
Estimate against measurement, compound 4: 1.7-fold (0.23 log units) above, and the stated range covers the measured number.
By their numbers in this assay, from the lowest: compound 1; then compound 4; then compound 3. At a limit, above all of these: compound 2.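

On the oxygen on a saturated carbon, acetyl in place of methyl gives a 2.8-fold lower number from compound 3 to compound 4 (0.44 log units; beyond the scatter), so this position responds to a change further out in the group and not only to the loss of methoxycarbonyl, yet acetoxymethyl does not close the gap to the ester, with a 2.7-fold higher number from compound 1 to compound 4 (0.43 log units; beyond the scatter). Against the methylcarbamoyl group, acetoxymethyl reads an at least 2.8-fold lower number from compound 2 to compound 4 (0.45 log units; beyond the scatter), which places the new ester on the lower side of the amide. Compound 2 holds a limit of the assay and not a number: the limit of > 10 ug/mL in this assay, at which 1 of the 4 values shown sits.

As far as these compounds go, whether the step follows the carbonyl of the acetyl or simply the longer group stays open; a free hydroxymethyl or a propionyl ester at this place would separate the two. From the compounds shown here alone, how a carboxylic acid in place of methoxycarbonyl would read also remains open.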